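The source may report more compounds than this note shows. Statements on the series, on what has been measured and on what is new or still open speak of the compounds shown alone.

Of the compounds shown here, three have so far been measured in a functional assay on BMDM cells (Mus musculus, strain C57BL/6) for inhibition, with a stated time of 2 days; a lower number here means a stronger inhibitor, a higher number a weaker inhibitor. Compound 1 `O=C(Cn1cc(-c2ccc([N+](=O)[O-])cc2)nn1)Nc1nccs1` gives 1040 nM, compound 2 `O=C(Cn1cc(-c2ccc([N+](=O)[O-])cc2)nn1)Nc1nc2ccccc2s1` gives 3280 nM, and compound 3 `Cc1csc(NC(=O)Cn2cc(-c3cccc(N)c3)nn2)n1` gives 250 nM. Compound 2 therefore carries the highest number of the three, meaning the weakest inhibition in this assay. For the measured compounds named here, the only single-place step recorded is a 3.2-fold higher number from compound 1 to compound 2 (0.50 log units; beyond the scatter), which changes the ring on the amide-type nitrogen, not the substituted phenyl ring. Compound 3 differs from compound 2 in more than one place, so its lower number shows only that other variants of the shared core inhibit more strongly.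

Compound 4 `N#Cc1ccc(-c2cn(CC(=O)Nc3nc4ccccc4s3)nn2)cc1` keeps everything of compound 2 except one group: cyano in place of nitro on an aromatic carbon. Going by the values given here, no measured step touches this position, so the measured data give no direct guide to the size or direction of the change in this assay. A step of no clear size beyond the scatter is therefore expected. On that basis compound 4 is estimated at 3000 nM, with a range from 1000 nM to 9000 nM. The expected step is a 1.1-fold lower number from compound 2 to compound 4 (0.04 log units; within the scatter).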

Compound 4, half-maximal inhibitory concentration: > 30000 nM
Compound 4 ended at the assay's limit; the forecaster's own chance of this, stated with the estimate: 10%; middle value at least 10-fold (1.00 log units) away from the limit.
By their numbers in this assay, from the lowest: compound 3; then compound 1; then compound 2. At a limit, above all of these: compound 4.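

In this assay, compound 4 gives > 30000 nM, which is a limit of the assay and not a number. Going from 4-nitrophenyl to 4-cyanophenyl brings an at least 9.1-fold higher number from compound 2 to compound 4 (0.96 log units; beyond the scatter), so this place on the aromatic ring, untouched by any earlier step, is not indifferent to the group it carries. The earlier step changed only the ring on the amide-type nitrogen, whereas this one shows that the substituted phenyl ring can also shift the number beyond the scatter.

As far as these compounds go, how far compound 4 lies past the limit stays unknown, and the full size of the step cannot be read: the limit of > 30000 nM in this assay, at which 1 of the 4 values shown sits. Also open is whether a carboxylic acid or a methoxy group at this place would behave like nitro or like cyano, and whether the same swap on compound 1 would give a similar step.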